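The compounds below may be only part of what the source reports. "The series", "measured", "known", "first", "only" and "open" are said of these compounds alone.

Of the compounds shown here, three with a shared chlorinated core have been measured so far. Compound 1 `Cc1ccccc1Nc1nc(NCc2ccncc2)ncc1Cl` gives only a limit in a functional assay on MDA-MB-231 cells (Homo sapiens) for inhibition, read by CCK-8 assay, with a stated time of 48 h (a higher number here means a weaker inhibitor of growth, a lower number a stronger inhibitor of growth), > 100000 nM. In this assay, compound 2 `Cc1ccccc1Nc1nc(Nc2ccc(N3CCCCC3)cc2)ncc1Cl` gives 19900 nM. Compound 3 `COc1cccc(CNc2nc(Nc3ccc(N4CCN(C)CC4)cn3)ncc2Cl)c1` gives 20300 nM in the same test, a value within the scatter of that of compound 2, so the two stand level, and neither reaches a low number.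

The next compound starts from compound 3. Compound 4 `CC(C)c1ccccc1Nc1nc(Nc2ccc(N3CCN(C)CC3)cn2)ncc1Cl` carries 2-isopropylphenyl in place of 3-methoxybenzyl on a nitrogen on an aromatic ring. The same difference, cut one bond further out, reads (3-methoxybenzyl)amino to (2-isopropylphenyl)amino.

Among the compounds with values here, no pair of measured compounds differs in this one place, so the size of the step cannot be read directly from the data. The expectation in this assay is therefore cautious: a moderate move toward a lower number, meaning a somewhat stronger inhibitor of growth, with no change beyond the scatter remaining quite possible. The expected change is a 2.3-fold lower number from compound 3 to compound 4 (0.35 log units; beyond the scatter). For compound 4 the estimated value is 9000 nM, with an expected range from 2000 nM to 40000 nM.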

Compound 4, concentration for 50% growth inhibition: 4090 nM
For compound 4 the middle estimate is 2.2-fold (0.34 log units) above the measured one; the range from low to high includes it.
By their numbers in this assay, from the lowest: compound 4; then compounds 2 and 3 (each within the scatter of the next). At a limit, above all of these: compound 1.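

In this assay, this place, on a nitrogen on an aromatic ring, now has a step that can be read, and it is not silent: putting 2-isopropylphenyl in place of 3-methoxybenzyl gives a 5.0-fold lower number from compound 3 to compound 4 (0.70 log units; beyond the scatter). The two groups match in their count of heavy atoms and each holds a six-membered aromatic ring of carbon only, yet the change also removes the methoxy oxygen, the one hydrogen-bond acceptor of the leaving group, and replaces a benzyl group with a phenyl group on that nitrogen. This single step joins these differences, and nothing measured here tells which of them carries the change or why the number moves.

As far as these compounds go, what stays open is how an unsubstituted phenyl or a 2-isopropylbenzyl group would stand on the same nitrogen, since these would separate the effect of the ring substituent from that of the benzyl link. Also open, from the compounds shown here alone, is whether a tert-butyl group or a plain methyl group in place of the isopropyl would shift the number of compound 4 from 4090 nM in this assay.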